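A few compounds are considered here, and "the series" means these few. Any claim that something is new, unique, unknown or untested is made for them only; others in the source may bear on it.

Measured in a functional assay on ileum (Cavia porcellus) for inhibition; on this read-out lower numbers stand for stronger inhibition and higher numbers for weaker inhibition
compound 1 `COC(=O)C1=C(C)NC(C)=C(C(=O)OC)C1c1c(-c2c(Cl)csc2Cl)nc2sc(C)cn12` with 3230 nM
compound 2 `COC(=O)C1=C(C)NC(C)=C(C(=O)OC)C1c1c(-c2cccs2)nc2sccn12` with 110 nM
compound 3 `COC(=O)C1=C(C)NC(C)=C(C(=O)OC)C1c1c(-c2ccsc2)nc2sc(C)cn12` with 3520 nM

Compound 2 at 110 nM holds the lowest number of the three, beyond the scatter from both of the others. Still unmeasured is compound 4 `COC(=O)C1=C(C)NC(C)=C(C(=O)OC)C1c1c(-c2ccncc2)nc2sccn12`, which differs from compound 2 in a single group: pyridin-4-yl in place of thiophen-2-yl on an aromatic carbon. In words, pyridin-4-yl stands in place of thiophen-2-yl on an aromatic carbon.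

Among the compounds with values here, only one measured step exchanges a ring on that carbon: a 1.1-fold higher number from compound 1 to compound 3 (0.04 log units; within the scatter). That step lies within the scatter, but it is weak guidance. Both of its rings are five-membered aromatic rings with 1 hetero atom, and the core of compound 1 is not the core of compound 2. Within the data shown here, no measured step brings in a six-membered aromatic ring, so the size of this change remains open.

With compound 2 at 110 nM, the lowest of the three, a move to a higher number is judged likelier than a move to a lower one. The step expected in this assay is modest, at a 2.3-fold higher number from compound 2 to compound 4 (0.36 log units; beyond the scatter), with wide uncertainty. For compound 4 the estimated value is 250 nM, with an expected range from 50 nM to 1200 nM.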

Compound 4, half-maximal inhibitory concentration: 960 nM
Compound 4: the middle estimate sits 3.8-fold (0.58 log units) below what was measured, within the range that was stated.
By their numbers in this assay, from the lowest: compound 2; then compound 4; then compounds 1 and 3 (each within the scatter of the next).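

Notes on the aromatic carbon of the five-membered aromatic ring with 2 nitrogen: in this assay the exchange of thiophen-2-yl for pyridin-4-yl on the shared core gives an 8.7-fold higher number from compound 2 to compound 4 (0.94 log units; beyond the scatter) and so shows that this position distinguishes between these two rings. Within the data shown here, the only earlier ring exchange on this carbon, a 1.1-fold higher number from compound 1 to compound 3 (0.04 log units; within the scatter) on a different core, kept to five-membered aromatic rings and gave no separation, so the present step is the first reading for a six-membered aromatic ring here. The two groups match in hydrogen-bond donor count, hydrogen-bond acceptor count and net charge while ring size and the hetero atom change together, and no supporting data on hand explain the step.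

From the compounds shown here alone, whether the step follows ring size or the identity of the hetero atom stays open, and phenyl or thiophen-3-yl on the core of compound 2 would help separate the two. The place of the ring nitrogen is equally unresolved, a question that pyridin-3-yl and pyridin-2-yl at this carbon would address.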